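A few compounds are considered here, and "the series" means these few. Any claim that something is new, unique, unknown or untested is made for them only; others in the source may bear on it.

Working notes on the series.

Compound 2 `Cc1nc2cc(C(=O)NCCC(C)(C)C)nn2c(-c2cc(F)c3c(c2C)CCCO3)c1[C@H](OC(C)(C)C)C(=O)O` is the reference point here. In an ADME assay on MT2 cells (Homo sapiens) for cytotoxicity (on this read-out lower numbers stand for higher toxicity in this test and higher numbers for lower toxicity in this test), compound 2 gives > 40000 nM, which is a limit of the assay rather than a measured number. Within the data shown here, compound 1 `Cc1nc2cc(C(=O)NCc3ccc(F)cc3O)nn2c(-c2cc(F)c3c(c2C)CCCO3)c1[C@H](OC(C)(C)C)C(=O)O` is the only other member measured, and in this assay compound 1 gives > 40000 nM, again a limit. Among the measured compounds shown here, the one step between measured compounds, a step that the two limits leave unreadable from compound 1 to compound 2, cannot be read in size because of the limit of > 40000 nM in this assay, at which 2 of the 2 values shown sit; it shows only that neither compound reached a measurable cytotoxic concentration.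

Compound 3 `Cc1nc2cc(C(=O)NCC3CCCCC3)nn2c(-c2cc(F)c3c(c2C)CCCO3)c1[C@H](OC(C)(C)C)C(=O)O` carries the change (cyclohexyl in place of neopentyl on a saturated chain carbon bound to an amide-type nitrogen). For the measured compounds named here, the only measured step that bears on this position is a step that the two limits leave unreadable from compound 1 to compound 2, and it is unreadable, so no direction or size can be drawn from it. With both known values sitting at the limit and no readable step at this position, a step beyond the usual scatter is not expected: the estimate is a step that the limit leaves unreadable from compound 2 to compound 3, with compound 3 most likely also reported as a limit. Compound 3 is estimated in this assay at 50000 nM, within 25000 nM to 120000 nM.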

Compound 3, half-maximal cytotoxic concentration: > 40000 nM
Compound 3: only a limit was reported; the forecaster's own chance of this, stated with the estimate: 85%; the middle value is on the limit's open side.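

No new step can be read in this assay for compound 3 against compound 1 or compound 2, because the result for compound 3 is again a limit and not a number: the limit of > 40000 nM in this assay, at which 3 of the 3 values shown sit.

The compounds shown leave open whether 3,3-dimethylbutyl and cyclohexylmethyl on the amide nitrogen differ at all in this assay, and what concentration, if any, would be cytotoxic.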